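From compound 3 to compound 4: bromo to iodo

This account rests on a few compounds, and the source may have more. Where it says the series, first, only, none or still open, it means among the compounds named here.

Among the compounds with values here, compound 3 `CC(C)(C)N(NC(=O)c1ccc(Br)cc1)C(=O)c1ccccc1Cl` gives the lowest number of the three measured so far in an assay on cells for agonist activity at ecdysone receptor (Bombyx mori), read by a luciferase reporter, with a stated time of 24 h (on this read-out lower numbers stand for an effect already at smaller amounts and higher numbers for an effect only at larger amounts of compound), at 33.9 nM. Compound 1 `CC(C)(C)N(NC(=O)c1ccccc1)C(=O)c1ccccc1Cl` gives 75.9 nM in this assay, and compound 2 `CC(C)(C)N(NC(=O)c1cccc(C#N)c1)C(=O)c1ccccc1Cl` gives 955 nM. Both steps down to compound 3 lie beyond the scatter, a 2.2-fold lower number from compound 1 to compound 3 (0.35 log units; beyond the scatter) and a 28-fold lower number from compound 2 to compound 3 (1.45 log units; beyond the scatter), so compound 3 stands as the most active of the set.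

Compound 4 `CC(C)(C)N(NC(=O)c1ccc(I)cc1)C(=O)c1ccccc1Cl` differs from compound 3 in one place: iodo in place of bromo on an aromatic carbon. Within the data shown here, no measured step exchanges one halogen for another. Among the measured compounds shown here, the only step at this position is a 2.2-fold lower number from compound 1 to compound 3 (0.35 log units; beyond the scatter), a modest change for bromo entering where hydrogen stood. The step of a 13-fold higher number from compound 1 to compound 2 (1.10 log units; beyond the scatter) concerns another group at another place and gives no direct guide. A swap between two halogens at the same position is expected to move the number less than the hydrogen-to-bromo step did, so the estimated step is a 1.4-fold lower number from compound 3 to compound 4 (0.13 log units; within the scatter), within or close to the scatter. Compound 4 is therefore expected to give about 25 nM in this assay, with a range from 10 nM to 70 nM.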

Compound 4, half-maximal effective concentration: 7.59 nM
Beside the measured number, compound 4's estimate is 3.3-fold (0.52 log units) above it, outside the stated range (below it).
By their numbers in this assay, from the lowest: compound 4; then compound 3; then compound 1; then compound 2.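

In this assay, exchanging one halogen for another at this position moves the number beyond the scatter, a 4.5-fold lower number from compound 3 to compound 4 (0.65 log units; beyond the scatter), so the position distinguishes iodo from bromo and not only a halogen from hydrogen. Iodo in place of hydrogen gives a 10-fold lower number from compound 1 to compound 4 (1.00 log units; beyond the scatter), and 4-iodophenyl in place of 3-cyanophenyl gives a 130-fold lower number from compound 2 to compound 4 (2.10 log units; beyond the scatter), which leaves compound 4 as the most active of the four. Nothing measured here gives a reason for the difference between iodo and bromo.

Still open, from the compounds shown here alone, is how the number responds when fluoro, chloro, or a non-halogen group such as methyl or methoxy stands at this position. Also open, going by these compounds, is whether the effect of iodo persists when another part of the shared core is changed.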